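Removing one fluoro from compound 3

This account rests on a few compounds, and the source may have more. Where it says the series, first, only, none or still open, it means among the compounds named here.

In an assay on FRT cells for positive allosteric modulation of Cystic fibrosis transmembrane conductance regulator variant N1303K (Homo sapiens), in the presence of a further agent that is not named here (on this read-out lower numbers stand for an effect already at smaller amounts and higher numbers for an effect only at larger amounts of compound), compound 3 `COc1ccc2[nH]c3c(c2c1)CCNC31CCN(Cc2ccc(F)c(F)c2F)CC1` gives 4100 nM, the lowest of the three numbers recorded. Compound 1 `COc1ccc2[nH]c3c(c2c1)CCNC31CCN(Cc2ccc(F)c(Cl)c2F)CC1` gives 4500 nM, and the step of a 1.1-fold lower number from compound 1 to compound 3 (0.04 log units; within the scatter) lies within the scatter. Compound 2 `COc1ccc2[nH]c3c(c2c1)CCNC31CCN(Cc2ccc(F)c(F)c2)CC1` gives 11000 nM; the step of a 2.7-fold lower number from compound 2 to compound 3 (0.43 log units; beyond the scatter) is beyond the scatter. Compound 4 `COc1ccc2[nH]c3c(c2c1)CCNC31CCN(Cc2cccc(F)c2F)CC1` differs from compound 3 by hydrogen in place of fluoro on an aromatic carbon. Among the compounds with values here, the one measured step that bears on this runs the other way: a 2.7-fold lower number from compound 2 to compound 3 (0.43 log units; beyond the scatter) showed a modestly lower number when a fluoro was added. Taking a fluoro away is therefore expected to give a modestly higher number, a 2.0-fold higher number from compound 3 to compound 4 (0.29 log units; within the scatter), though the fluoro removed here is not the one added there, so the size is uncertain. Compound 4 is estimated at 8000 nM, range 3500 nM to 18000 nM.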

Compound 4, half-maximal effective concentration: 13600 nM
The estimate for compound 4 lay 1.7-fold (0.23 log units) below the measured number; low and high end bracket the measured number.
By their numbers in this assay, from the lowest: compounds 3 and 1 (each within the scatter of the next); then compounds 2 and 4 (each within the scatter of the next).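

In this assay, the fluoro para to a large group carries weight of its own: its loss gives a step beyond the scatter (a 3.3-fold higher number from compound 3 to compound 4 (0.52 log units; beyond the scatter)). The two difluorophenyl compounds are not separated (a 1.2-fold higher number from compound 2 to compound 4 (0.09 log units; within the scatter)), whereas the chloro-bearing compound 1 stays apart from compound 4 (a 3.0-fold higher number from compound 1 to compound 4 (0.48 log units; beyond the scatter)), so among these four compounds the two with three halogens on the ring hold the lower numbers. No measurement on hand explains these steps.

Still open, going by these compounds, is how a methoxy or a nitrile at this place would compare with the fluoro. Also open, on these data alone, is whether chloro there would match it.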